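Notes on the step from compound 3 to compound 4

This account rests on a few compounds, and the source may have more. Where it says the series, first, only, none or still open, it means among the compounds named here.

Measured in a functional assay (blood) for inhibition, with Homo sapiens as the target; a higher number here means a weaker inhibitor, a lower number a stronger inhibitor:
- compound 1 `OC1O[C@H](CO/N=C2\CCc3cc(Sc4cc(F)cc(C5CCOCC5)c4)ccc32)[C@H](O)[C@H](O)[C@H]1O`: > 2500 nM (a limit)
- compound 2 `CO[C@]1(c2cnc(Sc3ccc(/C(C)=N/O)cc3)s2)CCO[C@@H](C)C1`: 40 nM
- compound 3 `CC(=O)/C(=N\O)c1ccc(Sc2cc(F)cc(C3CCOCC3)c2)cc1`: 850 nM

Compound 1 gives a limit and not a number. Of the two actual numbers, compound 2 gives 40 nM and compound 3 gives 850 nM. The gap between these two lies beyond the scatter, and compound 3 has the higher number. Compound 4 `CC(C)/C(=N\O)c1ccc(Sc2cc(F)cc(C3CCOCC3)c2)cc1` carries isopropyl in place of acetyl on a carbon with a double bond to nitrogen. Going by the values given here, no measured pair shows this change, so the expectation is loose: a slightly lower number in this assay, not beyond the scatter. The expected change is a 1.7-fold lower number from compound 3 to compound 4 (0.23 log units; within the scatter). The estimate for compound 4 is 500 nM, with an expected range of 130 nM to 2000 nM.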

Compound 4, half-maximal inhibitory concentration: 300 nM
For compound 4 the middle estimate is 1.7-fold (0.22 log units) above the measured one; the measured number falls inside the stated range.
By their numbers in this assay, from the lowest: compound 2; then compound 4; then compound 3. At a limit, above all of these: compound 1.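

Isopropyl in place of acetyl on a carbon with a double bond to nitrogen gives a 2.8-fold lower number from compound 3 to compound 4 (0.45 log units; beyond the scatter) in this assay, the only reading of a change in one place among the compounds shown. This position therefore responds to its substituent, and the acetyl with its hydrogen-bond acceptor is not required there. No measurement shown bears on the reason for this step.

Open, going by these compounds, is how an amine or a longer alkyl chain on that carbon would read in this assay. Also open, on these data alone, is whether the same change would carry over to the core of compound 2.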